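The compounds below may be only part of what the source reports. "The series", "measured", "known", "first", "only" and "open" are said of these compounds alone.

Working notes on the shared core of compound 1 `FC(F)(F)c1ccc(CSc2nc(Nc3ccccc3Cl)c3ccccc3n2)cc1`, followed in a functional assay on MDA-MB-231 cells (Homo sapiens) for cytotoxicity, read by MTT assay, with a stated time of 72 h; a lower number here means a stronger inhibitor, a higher number a weaker inhibitor. In this assay compound 1 gives > 50000 nM, which is a limit of the assay and not a number. For the measured compounds named here, compound 2 `Fc1ccc(Nc2nc(SCc3ccc(C(F)(F)F)cc3)nc3ccccc23)cc1` gives 15000 nM in this assay, the only number in the set. Going by the values given here, the one measured step, an at least 3.3-fold lower number from compound 1 to compound 2 (0.52 log units; beyond the scatter), is read against (the limit of > 50000 nM in this assay, at which 1 of the 2 values shown sits). Compound 3 `O=[N+]([O-])c1ccc(Nc2nc(SCc3ccc(C(F)(F)F)cc3)nc3ccccc23)cc1` differs from compound 2 by nitro in place of fluoro on an aromatic carbon, on the same aryl that the measured step exchanged. Among the compounds with values here, no measured step touches that substituent itself; the measured step, an at least 3.3-fold lower number from compound 1 to compound 2 (0.52 log units; beyond the scatter), shows the aryl on the nitrogen can shift the number at least modestly, so a step of comparable or smaller size in either direction is possible. The expectation for compound 3 is a step of a 1.5-fold lower number from compound 2 to compound 3 (0.18 log units; within the scatter), within or near the scatter. Compound 3 is therefore estimated at 10000 nM in this assay, with a range from 3000 nM to 40000 nM.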

Compound 3, half-maximal inhibitory concentration: 8670 nM
The estimate for compound 3 lay 1.2-fold (0.06 log units) above the measured number; measured number inside the range.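

In this assay, a 1.7-fold lower number from compound 2 to compound 3 (0.24 log units; within the scatter) shows that, on this aryl, fluoro and nitro cannot be told apart, although nitro adds two hydrogen-bond acceptors and more heavy atoms. Compound 3 also gives a second comparison with the 2-chlorophenyl compound, an at least 5.7-fold lower number from compound 1 to compound 3 (0.76 log units; beyond the scatter), so both the 4-fluorophenyl and the 4-nitrophenyl lie on the same side of that compound. Both comparisons rest on the value of compound 1, which is a limit of the assay and not a number: the limit of > 50000 nM in this assay, at which 1 of the 3 values shown sits.

As far as these compounds go, it remains open whether an amine or a carboxylic acid on the same aryl would move the number beyond the scatter. From the compounds shown here alone, the effect of any change to the rest of the shared core, which is the same in all three compounds, is also open.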